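The compounds below may be only part of what the source reports. "The series", "measured", "known", "first", "only" and "open" are said of these compounds alone.

Measured so far in a physicochemical assay for lipophilicity, read by HPLC, at pH 7.5; a lower number here means a more polar compound, a higher number a more lipophilic compound:
- compound 1 `CCOc1ccccc1-c1ccc(-c2nc3cnccc3c(N[C@H](CC)C(=O)N(C)C)c2C#N)cc1`: 3.7
- compound 2 `CCOc1ccccc1-c1ccc(-c2nc3cnccc3c(N[C@H](CC)C(N)=O)c2C#N)cc1`: 3
- compound 3 `CCOc1ccccc1-c1ccc(-c2nc3cnccc3c(NC(COC)C(N)=O)c2C#N)cc1`: 2.8

Compound 3, at 2.8, cannot be told apart from compound 2, while compound 1 stands clear of it, with a number 0.90 log units lower from compound 1 to compound 3 (beyond the scatter). Compound 4 `CCOc1ccccc1-c1ccc(-c2nc3cnccc3c(N[C@H](CC(C)C)C(N)=O)c2C#N)cc1` has 1-carbamoyl-3-methylbutyl in place of 1-carbamoyl-2-methoxyethyl on a nitrogen on an aromatic ring. The closest measured change on this nitrogen is a number 0.20 log units lower from compound 2 to compound 3 (within the scatter), and the other step that keeps the shared core, a number 0.70 log units lower from compound 1 to compound 2 (beyond the scatter), shows a modest size. Among the measured compounds shown here, no measured compound carries the entering group, which holds more carbon and less oxygen, so a modest rise in this assay is expected. The expected step is a number 0.70 log units higher from compound 3 to compound 4 (beyond the scatter). For compound 4 the estimate is 3.5, with an expected range from 3.1 to 3.9.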

Compound 4, distribution coefficient: 3.4
The estimate for compound 4 lay 0.10 log units above the measured number; the measured number falls inside the stated range.
By their numbers in this assay, from the lowest: compounds 3 and 2 (each within the scatter of the next); then compounds 4 and 1 (each within the scatter of the next).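

In this assay, the side chain on this nitrogen now gives steps beyond the scatter, unlike the earlier change here: the results are (a number 0.60 log units higher from compound 3 to compound 4 (beyond the scatter)) and (a number 0.40 log units higher from compound 2 to compound 4 (beyond the scatter)). With the carbamoyl group kept, 1-carbamoyl-3-methylbutyl cannot be told apart from the 1-(dimethylcarbamoyl)propyl of compound 1 (a number 0.30 log units lower from compound 1 to compound 4 (within the scatter)). Nothing available explains these steps. Still open, going by these compounds, is what a longer straight chain or a cyclohexyl group would give in this side chain. On these data alone, the step from a carboxylic acid in place of the carbamoyl group also stays open.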